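A chloro for fluoro swap on compound 2

The compounds below may be only part of what the source reports. "The series", "measured", "known", "first", "only" and "open" are said of these compounds alone.

Compound 2 `CNc1ncc(/C=C/c2c(F)cccc2F)cn1` has only a limit in a functional assay on LS174T cells (Homo sapiens) for antiproliferative activity (a lower number here means a stronger inhibitor, a higher number a weaker inhibitor), > 200 nM. Compound 3 `CCNc1ncc(/C=C/c2c(F)cccc2F)cn1` also has only a limit in this assay, > 200 nM. The data so far are marked by the limit of > 200 nM in this assay, at which 2 of the 3 values shown sit. Among the measured compounds shown here, the only measured step between close neighbours is a step that the two limits leave unreadable from compound 2 to compound 3, so it supplies no size to carry over. For the measured compounds named here, compound 1 `CN(C)c1ccc(/C=C/c2c(F)cccc2Cl)nc1` gives the one actual number in this assay, 20.4 nM.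

Compound 4 `CNc1ncc(/C=C/c2c(F)cccc2Cl)cn1` differs from compound 2 in one place: chloro in place of fluoro on an aromatic carbon, ortho to a large group and meta to a fluoro group. Going by the values given here, no measured step covers this swap. Among the compounds with values here, although it is not a one-place neighbour of compound 2, compound 1 also carries a chloro group, and its value of 20.4 nM is the only sign that such compounds can register a number in this assay. That makes a move towards stronger inhibition the likelier outcome, though another limit remains possible. An estimated step of an at least 2.0-fold lower number from compound 2 to compound 4 (0.30 log units; that floor lies within the scatter) is expected. For compound 4 the expected value is 100 nM, with an estimated range of 25 nM to 350 nM.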

Compound 4, half-maximal inhibitory concentration: > 200 nM
Compound 4: only a limit was reported; the forecaster's own chance of this, stated with the estimate: 35%; middle value at least 2.0-fold (0.30 log units) from the limit.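

Compound 4 gives only a limit in this assay, > 200 nM. Among the compounds shown here, compound 2 also stands at a limit there, so no step between compound 2 and compound 4 can be read. The compounds shown leave open whether chloro in place of fluoro on an aromatic carbon changes the activity of compound 2 at all.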